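The compounds below may be only part of what the source reports. "The series", "measured", "known", "first", "only" and "open" are said of these compounds alone.

Compound 1 `CC(C)c1n[nH]c2c(NCc3ccc(-c4ccccn4)cc3)nc(SCC(C)(C)N)nc12` and compound 2 `CNCCSc1nc(NCc2ccc(-c3ccccn3)cc2)c2[nH]nc(C(C)C)c2n1` share one core and differ only in the chain carried by the sulfur. In a functional assay on HT cells (Homo sapiens) for antiproliferative activity, read by fluorescence, with a stated time of 72 h (a higher number here means a weaker inhibitor of growth, a lower number a stronger inhibitor of growth), compound 1 gives 85 nM, while compound 2 gives 56 nM. The step of a 1.5-fold lower number from compound 1 to compound 2 (0.18 log units; within the scatter) is small, so the two compounds cannot be told apart on these numbers. Compound 2 has the lowest of the two values recorded, with compound 1 nearest to it and within the scatter of repeated measurements.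

Compound 3 `CCC(CO)Sc1nc(NCc2ccc(-c3ccccn3)cc2)c2[nH]nc(C(C)C)c2n1` is the next step from compound 2. The change is 1-(hydroxymethyl)propyl in place of 2-(methylamino)ethyl on a sulfur. For the measured compounds named here, the only measured step bearing on this sulfur chain, from compound 1 to compound 2, kept a nitrogen in the chain and produced no change beyond the scatter. Going by the values given here, compound 3 goes further, exchanging the nitrogen-bearing chain for one that carries an oxygen instead, and no measured pair shows what such an exchange does here. Compound 3 is therefore expected to give about 110 nM in this assay, within a range of 40 nM to 300 nM, meaning an expected step of a 2.0-fold higher number from compound 2 to compound 3 (0.29 log units; within the scatter).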

Compound 3, concentration for 50% growth inhibition: 255 nM
For compound 3 the middle estimate is 2.3-fold (0.37 log units) below the measured one, within the range that was stated.
By their numbers in this assay, from the lowest: compounds 2 and 1 (each within the scatter of the next); then compound 3.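

this assay shows that the chain on the sulfur can move the number beyond the scatter, which the step between the two nitrogen-bearing chains did not show. Replacing 2-(methylamino)ethyl with 1-(hydroxymethyl)propyl gives a 4.6-fold higher number from compound 2 to compound 3 (0.66 log units; beyond the scatter), and replacing 2-amino-2-methylpropyl with the same chain gives a 3.0-fold higher number from compound 1 to compound 3 (0.48 log units; beyond the scatter), so the oxygen-bearing chain stands apart from both nitrogen-bearing chains, and it does so although the counts of hydrogen-bond donors and acceptors are the same in 2-(methylamino)ethyl and 1-(hydroxymethyl)propyl. Nothing available explains this loss of growth inhibition.

The exchange changes the heteroatom and the carbon skeleton of the chain together, so these compounds cannot separate the part played by the oxygen in place of the nitrogen from the part played by the skeleton. A 1-(aminomethyl)propyl chain, which keeps the skeleton of compound 3 but carries an amine, and a 2-hydroxyethyl chain, which keeps the unbranched form of the chain in compound 2 but carries a hydroxyl, would each bear on that question.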